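From Ethyl to Cyclopentyl on a Very Weak Inhibitor

The source may hold more compounds than are shown below. What is called first, only, known or untested is meant among the compounds shown, and "the series" means these compounds.

Compound 1 `CCCCCC(=O)N[C@@H]1[C@H]2OC(C)(C)O[C@H]2O[C@@H]1[C@H](O)CO`: 10000000 nM
Compound 2 `CCC(=O)N[C@H]1[C@H]2OC(C)(C)O[C@H]2O[C@@H]1[C@H]1COC(C)(C)O1`: 7500000 nM

Both values come from a functional assay on K562 cells (Homo sapiens) for antiproliferative activity; a lower number here means a stronger inhibitor, a higher number a weaker inhibitor. Compound 2 has the lower of the two numbers, but it lies within the usual scatter of compound 1, so the two cannot be told apart. Both numbers are very high, which marks weak inhibition.

Compound 3 `CC1(C)O[C@H]2O[C@H]([C@H]3COC(C)(C)O3)[C@@H](NC(=O)C3CCCC3)[C@H]2O1` keeps the core of compound 2 and carries cyclopentyl in place of ethyl on a carbonyl carbon.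

Within the data shown here, the two measured compounds differ in more than one place, so no measured step shows what this swap does. With so little data, only a small change in this assay is expected, perhaps toward a slightly lower number. The estimated 1.5-fold lower number from compound 2 to compound 3 (0.18 log units; within the scatter) stays within the scatter. For compound 3 the estimated value is 5000000 nM, with an expected range of 1500000 nM to 12000000 nM.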

Compound 3, half-maximal inhibitory concentration: 1000000 nM
For compound 3 the middle estimate is 5.0-fold (0.70 log units) above the measured one; measured number below the stated range.
By their numbers in this assay, from the lowest: compound 3; then compounds 2 and 1 (each within the scatter of the next).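

In this assay, cyclopentyl in place of ethyl on a carbonyl carbon gives a 7.5-fold lower number from compound 2 to compound 3 (0.88 log units; beyond the scatter), so this position does respond to the group placed on it. Among these compounds, this is the only comparison here that changes one place, and it separates two compounds by more than the usual scatter. Even so, compound 3 at 1000000 nM still marks weak inhibition, and nothing shown explains the step.

Going by these compounds, whether the ring itself or simply the added carbon atoms go with the lower number stays open, and compound 1 cannot settle this, as it differs from compound 2 in more than one place. On these data alone, what a phenyl ring or a chain ending in an amine would do on the same carbonyl carbon also remains unknown.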